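Notes on removing the benzyl amide fluoro from compound 1

A few compounds are considered here, and "the series" means these few. Any claim that something is new, unique, unknown or untested is made for them only; others in the source may bear on it.

The series is read in an assay on cells for inhibition of Voltage-dependent T-type calcium channel subunit alpha-1G (Homo sapiens), read by patch clamp, tested at 10 uM; a higher number here means more inhibition at the concentration tested (going by the name of the read-out), a lower number less inhibition. Going by the values given here, compound 1 `O=C(CC1c2ccccc2N=C(SCCCCCN2CCCC2)N1c1ccc(-c2ccccc2)cc1)NCc1ccc(F)cc1` gives 51.5% in this assay; the only other number in hand, from compound 2 `O=C(CC1c2ccccc2N=C(SCCCCCN2CCCC2)N1c1ccccc1)NCc1ccc(F)cc1`, is 60.1%, and it lies within the scatter of compound 1, so the two compounds are not separated by the data. Among the compounds with values here, the single measured step, a number 8.6 percentage points higher from compound 1 to compound 2 (within the scatter), concerns a different part of the molecule from the change now at hand and itself stays within the scatter.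

Compound 3 `O=C(CC1c2ccccc2N=C(SCCCCCN2CCCC2)N1c1ccc(-c2ccccc2)cc1)NCc1ccccc1` differs from compound 1 by hydrogen in place of fluoro on an aromatic carbon. Within the data shown here, no measured step touches this end of the molecule, and the one comparison available, from compound 1 to compound 2 at another site, produced no movement beyond the scatter. With nothing in the data to support a shift in either direction, the step of a number 0.5 percentage points higher from compound 1 to compound 3 (within the scatter) is expected to stay within the scatter. Compound 3 is therefore estimated at 52% in this assay, with a range from 36% to 68%.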

Compound 3, a percentage reported as inhibition, at one concentration (the size of the read-out at that concentration, not a potency): 93.9%
For compound 3 the middle estimate is 41.9 percentage points below the measured one, and the stated range ends below it.
By their numbers in this assay, from the lowest: compounds 1 and 2 (each within the scatter of the next); then compound 3.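

Going by these compounds alone, the change from 4-fluorobenzyl to benzyl gives a number 42.4 percentage points higher from compound 1 to compound 3 (beyond the scatter) in this assay and is the first step to pass beyond the scatter, which shows that this end of the molecule can move the read-out strongly. The change is small in atoms, with one fluorine leaving and a hydrogen entering on an aromatic carbon para to a large group, and no ring, hydrogen-bond donor, hydrogen-bond acceptor or net charge is involved. Within the data shown here, nothing measured so far accounts for the size of this step at this position.

The compounds shown leave open whether a chloro, methyl or methoxy group at this same place would read like fluoro or like hydrogen, and so whether the step reflects the loss of fluoro specifically or a preference for an unsubstituted phenyl here. Going by these compounds, it is also open whether the step carries over to the core of compound 2, where the phenyl at the other site is replaced by hydrogen, as a number 8.6 percentage points higher from compound 1 to compound 2 (within the scatter) alone cannot say how the two changes combine.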